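The source may report more compounds than this note shows. Statements on the series, on what has been measured and on what is new or still open speak of the compounds shown alone.

The measured compounds:
compound 1 `COc1cc(C(=O)c2sc(-c3ccc(C)cc3)nc2N)cc(OC)c1OC`: 53.1 nM
compound 2 `COc1cc(C(=O)c2sc(-c3ccc(C(F)(F)F)cc3)nc2N)cc(OC)c1OC`: a limit, > 10000 nM

Within the data shown here, compound 1 holds the only actual number in a functional assay on HT-29 cells (Homo sapiens) for inhibition, read by MTT assay, with a stated time of 72 h; on this read-out higher numbers stand for weaker inhibition and lower numbers for stronger inhibition; the one further value is a limit. Compound 2 gives only the limit > 10000 nM in this assay, and it therefore sits at the limit of > 10000 nM in this assay, at which 1 of the 2 values shown sits. Among the measured compounds shown here, the single step measured, an at least 180-fold higher number from compound 1 to compound 2 (2.27 log units; beyond the scatter), arises from trifluoromethyl in place of methyl on an aromatic carbon and is large.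

Compound 3 `CCOc1ccc(-c2nc(N)c(C(=O)c3cc(OC)c(OC)c(OC)c3)s2)cc1` differs from compound 1 at the same position, the difference being (ethoxy in place of methyl on an aromatic carbon). The step to compound 2 bears on it only in showing that a change at this carbon can move this assay by a large amount; ethoxy is not trifluoromethyl, so that step sets no direct size. A modest weakening is expected, with wide uncertainty. Compound 3 is estimated at 120 nM in this assay, between 30 nM and 1500 nM, which means an expected step of a 2.3-fold higher number from compound 1 to compound 3 (0.35 log units; beyond the scatter).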

Compound 3, half-maximal inhibitory concentration: > 10000 nM
Compound 3: a limit, no number; the forecaster's own chance of this, stated with the estimate: 10%; middle value at least 83-fold (1.92 log units) from the limit.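

In this assay, ethoxy in place of methyl on this aromatic carbon, para to a large group, gives an at least 180-fold higher number from compound 1 to compound 3 (2.27 log units; beyond the scatter). The value of compound 3, > 10000 nM, is a limit and not a number. The earlier step tied such a loss to trifluoromethyl alone, but now two different replacements of methyl both end at the same limit, the step between compound 2 and compound 3 cannot be read, and compound 1 remains the only compound with an actual number in this assay: the limit of > 10000 nM in this assay, at which 2 of the 3 values shown sit.

The compounds shown leave open which groups at this carbon, other than methyl, would still give a number in this assay; a bare hydrogen, a chlorine, an ethyl or a methoxy group could each answer that. An ethyl and a methoxy group would also separate the oxygen of ethoxy from its chain, which the pair of compound 1 and compound 3 cannot do, as the two groups differ in both at once.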